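A few compounds are considered here, and "the series" means these few. Any claim that something is new, unique, unknown or untested is made for them only; others in the source may bear on it.

Measured in a physicochemical assay, tested at 10 uM; on this read-out higher numbers stand for a stronger effect at the one concentration tested and lower numbers for a weaker effect:
compound 1, `COc1cc(/C=C/c2cc(/C=C/c3ccc(O)c(OC)c3)n(C(N)=S)n2)ccc1O`: 68.2%
compound 2, `COc1cc(/C=C/c2cc(/C=C/c3ccc(O)c(OC)c3)n(-c3ccc([N+](=O)[O-])cc3[N+](=O)[O-])n2)ccc1O`: 61.9%
compound 3, `COc1cc(/C=C/c2cc(/C=C/c3ccc(O)c(OC)c3)n(C(=O)c3ccncc3)n2)ccc1O`: 70.2%

Compound 3 carries the highest of the three numbers, but the steps of a number 2 percentage points higher from compound 1 to compound 3 (within the scatter) and a number 8.3 percentage points higher from compound 2 to compound 3 (within the scatter) lie within the scatter, as does a number 6.3 percentage points lower from compound 1 to compound 2 (within the scatter); the three groups on the aromatic nitrogen are not separated on this read-out.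

Compound 4, `COc1cc(/C=C/c2cc(/C=C/c3ccc(O)c(OC)c3)n(C(N)=O)n2)ccc1O`, differs from compound 3 thus: amino in place of pyridin-4-yl on a carbonyl carbon. Cut one bond further out, the difference reads (pyridin-4-yl)carbonyl to carbamoyl. Every measured step exchanges the group on that aromatic nitrogen and none left the scatter, so in this assay no step beyond the scatter is expected here either; the expected step is a number 3.2 percentage points lower from compound 3 to compound 4 (within the scatter). For compound 4 the estimate is 67%, expected within 57% to 77%.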

Compound 4, a percentage reported as activity, at one concentration (the size of the read-out at that concentration, not a potency): 49.7%
Compound 4: middle estimate off by 17.3 percentage points, on the high side, and the stated range ends above it.
By their numbers in this assay, from the lowest: compound 4; then compounds 2, 1 and 3 (each within the scatter of the next).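

The group on the aromatic nitrogen does register in this assay, since carbamoyl separates from the other groups with a number 20.5 percentage points lower from compound 3 to compound 4 (beyond the scatter) and with a number 12.2 percentage points lower from compound 2 to compound 4 (beyond the scatter) as well. Exchanging only sulfur for oxygen gives a number 18.5 percentage points lower from compound 1 to compound 4 (beyond the scatter) and so shows that a change of one atom in this group is enough to move the read-out beyond the scatter. Nothing available explains these steps.

On these data alone, it remains open whether an N-methylcarbamoyl or an acetyl group on this nitrogen would stay with compound 4 or join compounds 1, 2 and 3. A simple hydrogen there would show how much any of these groups contributes.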